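A few compounds are considered here, and "the series" means these few. Any claim that something is new, unique, unknown or untested is made for them only; others in the source may bear on it.

Measured compounds:
Compound 1 `Fc1ccc2ncc(-c3nn[nH]n3)cc2c1` gives 50 mg/kg in a functional assay on the whole organism (strain Sprague-Dawley) for inhibition, with Rattus norvegicus as the target; on this read-out higher numbers stand for an effect only at larger amounts of compound and lower numbers for an effect already at smaller amounts.
Compound 2 `Fc1cc(F)c2ncc(-c3nn[nH]n3)cc2c1` reaches only a limit, > 50 mg/kg, in this assay.
Compound 3 `O=c1c(-c2nn[nH]n2)c[nH]c2ccccc12` reaches only a limit, > 20 mg/kg, in this assay.

Compounds 1 and 2 share one core and differ by fluoro in place of hydrogen on an aromatic carbon. The step of a number no lower from compound 1 to compound 2 (the limit leaves the size open) cannot be sized, since compound 2 sits at the limit of > 50 mg/kg in this assay, at which 1 of the 3 values shown sits. Compound 3 rests on another core; the difference between the two cores is not broken down here. Compound 3 stands at the limit of > 20 mg/kg in this assay, at which 1 of the 3 values shown sits.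

Compound 4 `O=c1c(-c2nn[nH]n2)c[nH]c2c(F)cccc12` has not yet been measured in this assay. It differs from compound 3 by fluoro in place of hydrogen on an aromatic carbon. This is the same kind of change as that from compound 1 to compound 2, though not the same: in compound 2 the entering fluoro is also meta to a fluoro group, which is not so in compound 4. The earlier step, a number no lower from compound 1 to compound 2 (the limit leaves the size open), showed no gain from the change, so compound 4 is expected to show a step that the limit leaves unreadable from compound 3 to compound 4 against compound 3. The estimate for compound 4 is 30 mg/kg, between 10 mg/kg and 100 mg/kg, with a real chance that only a limit is reported.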

Compound 4, minimum effective dose: 10 mg/kg
Estimate against measurement, compound 4: 3.0-fold (0.48 log units) above; the range from low to high includes it.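

In this assay the fluoro change gives an at least 2.0-fold lower number from compound 3 to compound 4 (0.30 log units; that floor lies within the scatter), and this step rests on a limit, since compound 3 reaches only > 20 mg/kg. On the core of compound 3, then, the entering fluoro goes with a number that is measured rather than limited, whereas on the core of compound 1 the same kind of change brought no lower number, so the two cores cannot be said to share one outcome, and the comparison stays unsized: the same change on two cores in this assay, a number no lower (the limit leaves the size open) from compound 1 to compound 2 and an at least 2.0-fold lower number (0.30 log units; that floor lies within the scatter) from compound 3 to compound 4; the limit leaves it open whether they differ. This does not show that the two cores truly respond differently to fluoro, nor that they respond alike, and it gives no true size for either step.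

The compounds shown leave open what a fluoro group on the other aromatic carbons of the core of compound 3 would give. They also leave open whether a chloro group, a methoxy group or an amine on the same aromatic carbon would go with a number like that of compound 4, which gives 10 mg/kg.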